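From benzoyl to dichlorophenyl in a cell-toxicity test

The source may report more compounds than this note shows. Statements on the series, on what has been measured and on what is new or still open speak of the compounds shown alone.

Measured so far in an ADME assay on BJ cells (Homo sapiens) for cytotoxicity, with a stated time of 72 h; on this read-out lower numbers stand for an effect already at smaller amounts and higher numbers for an effect only at larger amounts of compound
- compound 1 `C=C[C@@](C)(/C=C/c1ccc(O)cc1)CCC=O` gives > 36600 nM (a limit)
- compound 2 `C=C[C@@](C)(/C=C/c1ccc(O)c(/C=C/C(=O)c2ccccc2)c1)CCC=C(C)C` gives > 20000 nM (a limit)
- compound 3 `C=C[C@@](C)(/C=C/c1ccc(O)c(/C=C(\C)C(=O)OCC)c1)CCC=C(C)C` gives > 36600 nM (a limit)

None of the three entries is a true number, so each one marks only the edge of what this assay reported. Compound 2 gives > 20000 nM as its result, and this too is a limit of the assay and not a number. Going by the values given here, its position on the scale is therefore not pinned down, and no measured pair of compounds differs in just one place to show how large a single change can be.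

The next compound is compound 4 `C=C[C@@](C)(/C=C/c1ccc(O)c(/C=C/c2ccc(Cl)c(Cl)c2)c1)CCC=C(C)C`. The change is 3,4-dichlorophenyl in place of benzoyl on a double-bonded chain carbon bound to a double-bonded chain carbon and in words it places 3,4-dichlorophenyl in place of benzoyl on a double-bonded chain carbon bound to a double-bonded chain carbon.

With only limits to go on, no clear shift in this assay is expected in either direction. The estimated step that the limit leaves unreadable from compound 2 to compound 4 stays within the usual scatter of this measurement. The result may well come back as a limit again. For compound 4 the estimated value is 25000 nM with an expected range from 9000 nM to 60000 nM around it.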

Compound 4, half-maximal effective concentration: > 13000 nM
Compound 4 was reported as a limit; the forecaster's own chance of this, stated with the estimate: 65%; the middle value does not contradict the limit.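

Compound 2 gives > 20000 nM in this assay, and this is a limit of the assay. Compound 4 gives > 13000 nM, which is also a limit, so the step from compound 2 to compound 4 cannot be read. The compounds shown leave open where any of them truly lies on the scale of this assay.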